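This account rests on a few compounds, and the source may have more. Where it says the series, first, only, none or still open, it means among the compounds named here.

Measured so far:
Compound 1 `N#CC1=C(N)Oc2c(c3nc4ccccc4nc3c3ccccc23)C12C(=O)N(Cc1cnnn1-c1ccc(Cl)cc1)c1ccccc12` — in a functional assay on HCT-116 cells (Homo sapiens) for antiproliferative activity, read by MTT assay, with a stated time of 48 h (a lower number here means a stronger inhibitor, a higher number a weaker inhibitor), compound 1 gives > 50000 nM, a limit of the assay.
Compound 2 `N#CC1=C(N)Oc2c(c3nc4ccccc4nc3c3ccccc23)C12C(=O)N(Cc1cnnn1-c1ccc(Br)cc1)c1ccccc12` — in this assay compound 2 gives > 50000 nM, again a limit.
Compound 3 `COc1ccc(-n2nncc2CN2C(=O)C3(C(C#N)=C(N)Oc4c(N)cc5nc6ccccc6nc5c43)c3ccccc32)cc1` — in this assay compound 3 gives > 50000 nM, also a limit.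

For the measured compounds named here, the one recorded step, a step that the two limits leave unreadable from compound 1 to compound 2, cannot be read because both values sit at the limit of > 50000 nM in this assay, at which 3 of the 3 values shown sit. Compound 3 stands at that same limit, so nothing measured separates it from the others. Compound 4 `N#CC1=C(N)Oc2c(N)cc3nc4ccccc4nc3c2C12C(=O)N(Cc1cnnn1-c1c(Cl)cc(Cl)cc1Cl)c1ccccc12` differs from compound 3 by 2,4,6-trichlorophenyl in place of 4-methoxyphenyl on an aromatic nitrogen. Going by the values given here, no measured step bears on this change; the only step available is unreadable, and all values so far are limits. Compound 4 is therefore expected in this assay to give 60000 nM, range 10000 nM to 200000 nM, most likely reported as a limit again. The implied step that the limit leaves unreadable from compound 3 to compound 4 is expected to be none beyond the scatter.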

Compound 4, half-maximal inhibitory concentration: 12100 nM
Compound 4: the middle estimate sits 5.0-fold (0.70 log units) above what was measured; the measured number falls inside the stated range.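

For the compounds shown here, replacing 4-methoxyphenyl with 2,4,6-trichlorophenyl on this aromatic nitrogen gives in this assay an at least 4.1-fold lower number from compound 3 to compound 4 (0.61 log units; beyond the scatter) and is the only readable step so far. The group on this nitrogen can therefore move the read-out, and compound 4 alone of the four compounds shown has a value that is not a limit. The step is only a bound, as compound 3 stands at a limit: the limit of > 50000 nM in this assay, at which 3 of the 4 values shown sit.

From the compounds shown here alone, whether one chlorine or all three matter on the core of compound 4 remains open. Also open, going by these compounds, is how an amine or a carboxylic acid on this phenyl ring would read.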